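Notes on a bis-sulfonylbenzene piperidine series

The source may report more compounds than this note shows. Statements on the series, on what has been measured and on what is new or still open speak of the compounds shown alone.

Of the compounds shown here, three have been measured in a functional assay on MIA PaCa-2 cells (Homo sapiens) for inhibition, read by MTT assay, with a stated time of 3 days; on this read-out higher numbers stand for weaker inhibition and lower numbers for stronger inhibition. Compound 1 `CCN(CC)S(=O)(=O)c1ccc(S(=O)(=O)N2CCC[C@@H](C(=O)N(C)C(C)C)C2)cc1` gives in this assay only the limit > 10000 nM, not a number. Compound 3 `CCOC(=O)C12CC(CN(S(=O)(=O)c3ccc(S(=O)(=O)N(CC)CC)cc3)C1)C2` likewise reaches only the limit > 10000 nM in this assay. Compound 2 `CCN(CC)C(=O)c1ccc(S(=O)(=O)N2CCC[C@@H](C(=O)N3CCN(c4nc(C(C)C)no4)CC3)C2)cc1` stands at the limit > 10000 nM in this assay, again a limit and not a measured number, in line with the limit of > 10000 nM in this assay, at which 3 of the 3 values shown sit. Within the data shown here, no step between measured compounds can be drawn. Compound 4 `CC(C)c1noc(N2CCN(C(=O)[C@@H]3CCCN(S(=O)(=O)c4ccc(S(=O)(=O)NC5CCC5)cc4)C3)CC2)n1` differs from compound 2 by cyclobutylsulfamoyl in place of diethylcarbamoyl on an aromatic carbon. With every measured compound at the limit, the expected step is a step that the limit leaves unreadable from compound 2 to compound 4, nothing beyond the scatter. For compound 4 the estimated value in this assay is 15000 nM, with a range from 5000 nM to 50000 nM, most likely reported as a limit again.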

Compound 4, half-maximal inhibitory concentration: > 10000 nM
Compound 4 gave a limit, no number; the forecaster's own chance of this, stated with the estimate: 80%; the middle value is on the limit's open side.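

In this assay, among these compounds, compound 4 gives > 10000 nM as a limit and not a number, so no step from compound 2 to compound 4 can be read. The compounds shown leave open whether any change on the shared core gives a measured number in this assay at all: the limit of > 10000 nM in this assay, at which 4 of the 4 values shown sit.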